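Methyl in Place of Cyano on the Sulfonyl Aryl Ring

The source may report more compounds than this note shows. Statements on the series, on what has been measured and on what is new or still open speak of the compounds shown alone.

Among the measured compounds shown here, compound 3 `CC1CCN(c2c(S(=O)(=O)c3ccc(C#N)cc3)cnc3ccc(F)cc23)CC1` stands lowest of the three compounds measured so far in an assay on isolated protein for displacement of a labelled ligand from metabotropic glutamate receptor 5 (Homo sapiens), with a stated time of 60 min, tested at 1 uM (a lower number here means less inhibition, a higher number more inhibition at the concentration tested (going by the name of the read-out)), giving 75%. Compound 1 `COc1cccc(S(=O)(=O)c2cnc3ccc(F)cc3c2N2CCC(C)CC2)c1` gives 90% in this assay, and compound 2 `CC1CCN(c2c(S(=O)(=O)c3cccc(Cl)c3)cnc3ccc(F)cc23)CC1` gives 92%. Both steps that lead into compound 3 alter the aryl group on the sulfonyl sulfur: a number 15 percentage points lower from compound 1 to compound 3 (beyond the scatter), and a number 17 percentage points lower from compound 2 to compound 3 (beyond the scatter). The step between the two higher compounds, a number 2 percentage points higher from compound 1 to compound 2 (within the scatter), shows that chloro in place of methoxy left the read-out essentially unchanged.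

Compound 4 `Cc1ccc(S(=O)(=O)c2cnc3ccc(F)cc3c2N2CCC(C)CC2)cc1` differs from compound 3 in a single place: methyl in place of cyano on an aromatic carbon. For the measured compounds named here, the change removes the cyano that sets compound 3 apart from compounds 1 and 2, though none of the measured compounds carries a methyl on that ring, so the new group itself is untested.

Because a number 15 percentage points lower from compound 1 to compound 3 (beyond the scatter) and a number 17 percentage points lower from compound 2 to compound 3 (beyond the scatter) both run downward when cyano is introduced, the reverse move is expected to recover part of that loss, estimated as a number 10 percentage points higher from compound 3 to compound 4 (within the scatter). Compound 4 is therefore estimated at 85% in this assay, within a range of 72% to 95%.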

Compound 4, a percentage reported as inhibition, at one concentration (the size of the read-out at that concentration, not a potency): 91%
Compound 4: middle estimate off by 6 percentage points, on the low side; low and high end bracket the measured number.
By their numbers in this assay, from the lowest: compound 3; then compounds 1, 4 and 2 (each within the scatter of the next).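

Among the compounds shown here, with methyl in place of cyano at this position, para to a large group, this assay shows a number 16 percentage points higher from compound 3 to compound 4 (beyond the scatter), the first step in which only the group at this carbon changes. The earlier compounds could not separate the cyano group from its place on the ring, since compounds 1 and 2 carry different groups at a different place, whereas compound 4 keeps a group at the same carbon as compound 3 and still shows a number 1 percentage points lower from compound 2 to compound 4 (within the scatter) and a number 1 percentage points higher from compound 1 to compound 4 (within the scatter), so among these compounds a group at this carbon does not by itself go with the lower number, and only the cyano-bearing compound 3 stands apart. Nothing measured here explains why cyano and methyl differ at this carbon.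

Compounds 1, 2 and 4 lie within the scatter of one another at a single concentration in this assay, so the read-out leaves their relative potency open. As far as these compounds go, it also remains open whether other groups at this carbon, such as an amine, a carboxylic acid or a longer chain, would give numbers like that of the methyl compound 4 or like that of the cyano compound 3.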